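Compound 3: isopropyl replaces the 2,4-dichlorophenyl group

The source may report more compounds than this note shows. Statements on the series, on what has been measured and on what is new or still open speak of the compounds shown alone.

Compound 1 `COc1cc(/C=C/C(=O)c2cccc(NC(=O)c3ccco3)c2)ccc1O` gives 3.11 ug/mL
Compound 2 `COc1cc(/C=C/C(=O)c2cccc(NC(=O)c3ccc(Cl)cc3Cl)c2)ccc1O` gives 27.2 ug/mL

In a functional assay on Vero cells (Chlorocebus sabaeus) for inhibition (a higher number here means a weaker inhibitor, a lower number a stronger inhibitor), compound 2 holds the higher of the two numbers (27.2 ug/mL). Compound 3 `COc1cc(/C=C/C(=O)c2cccc(NC(=O)C(C)C)c2)ccc1O` keeps the shared core but differs at one place (isopropyl in place of 2,4-dichlorophenyl on a carbonyl carbon). Among the compounds with values here, one measured step bears on this place: an 8.7-fold higher number from compound 1 to compound 2 (0.94 log units; beyond the scatter), which came with 2,4-dichlorophenyl in place of furan-2-yl on a carbonyl carbon. Removing 2,4-dichlorophenyl is therefore expected to lower the number, although this single step says nothing direct about isopropyl. The expected change is a 2.7-fold lower number from compound 2 to compound 3 (0.43 log units; beyond the scatter). For compound 3 the estimated value is 10 ug/mL, with an expected range from 3 ug/mL to 30 ug/mL.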

Compound 3, half-maximal inhibitory concentration: 3.47 ug/mL
Compound 3: middle estimate off by 2.9-fold (0.46 log units), on the high side; the range from low to high includes it.
By their numbers in this assay, from the lowest: compounds 1 and 3 (each within the scatter of the next); then compound 2.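

In this assay, the position on the carbonyl carbon turns out not to need a ring, since the non-ring isopropyl group recovers what 2,4-dichlorophenyl gave up (a 7.8-fold lower number from compound 2 to compound 3 (0.89 log units; beyond the scatter)). Isopropyl and furan-2-yl cannot be told apart here (a 1.1-fold higher number from compound 1 to compound 3 (0.05 log units; within the scatter)), so among these three compounds only compound 2 stands apart. Nothing measured accounts for this. As far as these compounds go, whether the chlorines or the six-membered aromatic ring itself sets compound 2 apart stays open, as does how an unsubstituted phenyl, a longer chain or an amine would read at this place.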